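Methyl for Chloro on the Aryl Arm

A few compounds are considered here, and "the series" means these few. Any claim that something is new, unique, unknown or untested is made for them only; others in the source may bear on it.

Compound 1 `Cc1ccc(-c2ccnc(C(=O)Nc3ccc(Oc4ccnc5[nH]ccc45)cc3)c2)cc1`: > 10000 nM
Compound 2 `O=C(Nc1ccc(Oc2ccnc3[nH]ccc23)cc1)c1cc(-c2ccc(Cl)cc2)ccn1`: 25100 nM

In a functional assay on PC-3 cells (Homo sapiens) for cytotoxicity, read by MTT assay, with a stated time of 72 h (on this read-out higher numbers stand for weaker inhibition and lower numbers for stronger inhibition), compound 2 gives 25100 nM, the only number among these two compounds. For compound 1 this assay reports only a limit, > 10000 nM. The step that the limit leaves unreadable from compound 1 to compound 2 cannot be sized because the limit of > 10000 nM in this assay, at which 1 of the 2 values shown sits, conceals one end of it. Compound 3 `Cc1cccc(-c2ccnc(C(=O)Nc3ccc(Oc4ccnc5[nH]ccc45)cc3)c2)c1` differs from compound 2 by 3-methylphenyl in place of 4-chlorophenyl on an aromatic carbon. Among the compounds with values here, no measured step of readable size bears on this change, so no shift beyond the scatter is expected in this assay. Compound 3 is therefore estimated at 20000 nM, within 8000 nM to 50000 nM. The expected step is a 1.3-fold lower number from compound 2 to compound 3 (0.10 log units; within the scatter).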

Compound 3, half-maximal inhibitory concentration: 5470 nM
For compound 3 the middle estimate is 3.7-fold (0.56 log units) above the measured one, and the stated range ends above it.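

In this assay, within the data shown here, the aryl arm turns out to respond to change at this position, with the first readable step on it: a 4.6-fold lower number from compound 2 to compound 3 (0.66 log units; beyond the scatter). The 3-methylphenyl group in place of 4-methylphenyl gives an at least 1.8-fold lower number from compound 1 to compound 3 (0.26 log units; that floor lies within the scatter). The step from compound 1 to compound 2 still cannot be read, and the same limit bounds the comparison with compound 3: the limit of > 10000 nM in this assay, at which 1 of the 3 values shown sits.

The compounds shown do not separate the effect of the methyl from that of its place on the ring, since a 3-chlorophenyl group stands among none of them. Going by these compounds, how a methoxy group or an amine would read on this arm also stays open.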